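The compounds below may be only part of what the source reports. "The series", "measured", "known", "first", "only" and "open" are said of these compounds alone.

In a functional assay on Shh Light II cells (Mus musculus) for inhibition, read by a luciferase reporter (a higher number here means a weaker inhibitor, a lower number a stronger inhibitor), two compounds sharing one core have been measured so far. Compound 1 (`O=C(NC1CCC(O)CC1)N1CCC(c2nc(-c3ccc4ccccc4n3)no2)CC1`) gives 2700 nM, while compound 2 (`CC(=O)N1CCC(NC(=O)N2CCC(c3nc(-c4ccc5ccccc5n4)no3)CC2)CC1`) gives 500 nM, the lower of the two numbers and so the stronger inhibitor. Compound 3 (`COc1ccccc1N(C)C(=O)N1CCC(c2nc(-c3ccc4ccccc4n3)no2)CC1`) keeps the core and has (2-methoxyphenyl)(methyl)amino in place of (1-acetylpiperidin-4-yl)amino on a carbonyl carbon. Among the compounds with values here, only one measured step bears on this place, and it involves no aromatic ring in the changing group, so it is a limited guide. That step, a 5.4-fold lower number from compound 1 to compound 2 (0.73 log units; beyond the scatter), is modest but beyond the scatter, so a step of similar modest size is expected here, tentatively towards a lower number. The estimated change is a 4.2-fold lower number from compound 2 to compound 3 (0.62 log units; beyond the scatter). For compound 3 the expected value is 120 nM, with an estimated range of 12 nM to 1200 nM.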

Compound 3, half-maximal inhibitory concentration: 3100 nM
Compound 3: the middle estimate sits 26-fold (1.41 log units) below what was measured; measured number above the stated range.
By their numbers in this assay, from the lowest: compound 2; then compounds 1 and 3 (each within the scatter of the next).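

At this place on a carbonyl carbon, this assay shows that the gain seen with (1-acetylpiperidin-4-yl)amino does not carry over to (2-methoxyphenyl)(methyl)amino, the change giving a 6.2-fold higher number from compound 2 to compound 3 (0.79 log units; beyond the scatter) and so moving the number away from that of the stronger compound. Against the (4-hydroxycyclohexyl)amino group, the same aromatic group gives a 1.1-fold higher number from compound 1 to compound 3 (0.06 log units; within the scatter), so two quite different groups stand level and, among these three, only compound 2 stands apart. Nothing measured here accounts for this difference.

Going by these compounds, it remains open whether the advantage of compound 2 rests on its acetyl group or on the piperidine ring itself, and a piperidine with a free amine would bear on that. On these data alone, it is also open what the methyl and methoxy groups of compound 3 each contribute, which a plain phenyl group on the amide-type nitrogen could help to separate.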